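Solubility notes: compound 4 against the measured set

The compounds below may be only part of what the source reports. "The series", "measured", "known", "first", "only" and "open" are said of these compounds alone.

In a physicochemical assay for solubility, with a stated time of 18 h, at pH 7.4 (on this read-out higher numbers stand for higher solubility and lower numbers for lower solubility), compound 3 `CCC(CC)c1ccc2c(NCCCNCc3ccco3)ccnc2c1` gives 4200 nM. It stands level with compound 2 `Fc1ccc(Cc2ccc3c(NCCCNCc4ccco4)ccnc3c2)cc1`, which in this assay gives 4200 nM; the two together are the lowest numbers of the three measured. Compound 1 `CC(C)(C)c1ccc(Oc2ccc3c(NCCCNCc4ccco4)ccnc3c2)cc1` gives 14500 nM in this assay, a higher number than compound 3, beyond the scatter.

Compound 4 `COc1ccc(Oc2ccc3c(NCCCNCc4ccco4)ccnc3c2)cc1` differs from compound 3 by 4-methoxyphenoxy in place of pentan-3-yl on an aromatic carbon. Among the compounds with values here, the only measured step, no change at the digits printed from compound 2 to compound 3 (within the scatter), shows that exchanging one hydrocarbon group for another at this carbon left the number where it was; it does not cover the entry of a group with two oxygens and a ring. Of the measured compounds, compound 1 is the closest relative of compound 4, and its value in this assay is the highest of the three. The expected step is therefore a rise, a 2.1-fold higher number from compound 3 to compound 4 (0.33 log units; beyond the scatter), beyond the scatter. Compound 4 is estimated at 9000 nM in this assay, with a range from 3500 nM to 22000 nM.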

Compound 4, solubility: 14500 nM
Compound 4: the middle estimate sits 1.6-fold (0.21 log units) below what was measured; the measured number falls inside the stated range.
By their numbers in this assay, from the lowest: compounds 2 and 3 (each within the scatter of the next); then compounds 1 and 4 (each within the scatter of the next).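

In this assay, 4-methoxyphenoxy on this aromatic carbon gives a 3.5-fold higher number from compound 3 to compound 4 (0.54 log units; beyond the scatter) in place of pentan-3-yl and a 3.5-fold higher number from compound 2 to compound 4 (0.54 log units; beyond the scatter) in place of 4-fluorobenzyl, so this position does respond to the group it carries. Methoxy in place of tert-butyl on the phenoxy ring gives no change at the digits printed from compound 1 to compound 4 (within the scatter) and so leaves no readable difference in that pair. Across the four compounds shown, the two higher numbers belong to the compounds with a substituted phenoxy group at this carbon, and no compound shown goes against this.

From the compounds shown here alone, whether the linking oxygen or the aromatic ring goes with the rise remains open, as does the reading for a phenoxy group bearing an amine or a carboxylic acid. No supporting measurement accounts for the steps at this position.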